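Methoxy in place of hydrogen on the benzoyl ring

The source may report more compounds than this note shows. Statements on the series, on what has been measured and on what is new or still open speak of the compounds shown alone.

Of the compounds shown here, two have been measured in a physicochemical assay for lipophilicity; on this read-out lower numbers stand for lower lipophilicity and higher numbers for higher lipophilicity. Compound 1 `O=C(c1ccc(Cl)cc1)n1c(-c2ccccc2[N+](=O)[O-])nc2ccccc21` gives 3.6 in this assay. Compound 2 `O=C(c1ccccc1)n1c(-c2ccccc2[N+](=O)[O-])nc2ccccc21` gives 3.1 in this assay. Within the data shown here, the one step between them, a number 0.50 log units lower from compound 1 to compound 2 (beyond the scatter), is the only measured step in the set. Compound 2 therefore stands at the lowest of the two numbers in this assay, with compound 1 its nearest neighbour at a number beyond the scatter above it.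

Compound 3 `COc1ccc(C(=O)n2c(-c3ccccc3[N+](=O)[O-])nc3ccccc32)cc1` has not yet been measured. It differs from compound 2 in one place: methoxy in place of hydrogen on an aromatic carbon. Among the measured compounds shown here, no measured step in this set involves a methoxy group; the step from compound 1 to compound 2 concerns a chloro group and does not bear directly on this change. From the two measured compounds alone there is no basis for expecting a shift in either direction in this assay beyond the scatter. Compound 3 is therefore expected to give a number close to that of compound 2, with an estimated step of no change at the digits printed from compound 2 to compound 3 (within the scatter), and the estimate for compound 3 in this assay is 3.1, within a range from 2.7 to 3.5.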

Compound 3, partition coefficient: 3.2
Estimate against measurement, compound 3: 0.10 log units below; measured number inside the range.
By their numbers in this assay, from the lowest: compounds 2 and 3 (each within the scatter of the next); then compound 1.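

In this assay, putting methoxy in place of hydrogen on an aromatic carbon, para to a large group, gives a number 0.10 log units higher from compound 2 to compound 3 (within the scatter), so at this position the change from phenyl to 4-methoxyphenyl does not separate the two compounds on this read-out. Among these compounds, the same position also gives the first comparison of two substituents rather than of a substituent with hydrogen: methoxy in place of chloro gives a number 0.40 log units lower from compound 1 to compound 3 (beyond the scatter), and with a number 0.50 log units lower from compound 1 to compound 2 (beyond the scatter) alongside it, compound 1 stands apart from both of the others, while the result for methoxy stays within the scatter of the result for hydrogen. Nothing available explains why chloro and methoxy differ here on this read-out.

The compounds shown leave open whether a longer chain such as ethoxy, an amine or a carboxylic acid at this same aromatic carbon would stay within the scatter of compound 2 or stand apart from it as compound 1 does. They also leave open whether methoxy in place of hydrogen would give a similar result elsewhere on this ring or on the other aromatic rings of the shared core.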